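Working notes: exchanging the group on the ether oxygen

The source may hold more compounds than are shown below. What is called first, only, known or untested is meant among the compounds shown, and "the series" means these compounds.

- compound 1 `COc1ccc(/C=C/C(=O)c2ccc(-n3cc(COc4ccc5ccc(=O)oc5c4)nn3)cc2)c(OC)c1OC` gives 22500 nM
- compound 2 `COc1cc(/C=C/C(=O)c2ccc(-n3cc(COc4ccc5ccc(=O)oc5c4)nn3)cc2)cc(OC)c1OC` gives 79500 nM

Among the compounds with values here, in a functional assay on MOLT-3 cells (Homo sapiens) for cytotoxicity, read by XTT assay, with a stated time of 48 h (a higher number here means a weaker inhibitor, a lower number a stronger inhibitor), compound 1 has the lower of the two numbers, with a 3.5-fold higher number from compound 1 to compound 2 (0.55 log units; beyond the scatter) as the only measured step. The change to compound 3 `COc1ccc(/C=C/C(=O)c2ccc(-n3cc(COc4cc(=O)oc5ccccc45)nn3)cc2)c(OC)c1OC` is a group of 11 heavy atoms (9 carbon, 2 oxygen; one six-membered aromatic ring of carbon only, one six-membered aromatic ring with 1 hetero atom) in place of a group of 11 heavy atoms (9 carbon, 2 oxygen; one six-membered aromatic ring of carbon only, one six-membered aromatic ring with 1 hetero atom), on an oxygen on a saturated carbon and the same atoms are joined differently. The measured step lies at a different place in the molecule, so it gives only a rough scale and no direction. A modest step in either direction is therefore expected, and the estimated central step is a 1.1-fold higher number from compound 1 to compound 3 (0.05 log units; within the scatter) with wide uncertainty. For compound 3 an estimated value of 25000 nM is expected, with a range of 8000 nM to 75000 nM for this measurement.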

Compound 3, half-maximal inhibitory concentration: 12300 nM
For compound 3 the middle estimate is 2.0-fold (0.31 log units) above the measured one; the range from low to high includes it.
By their numbers in this assay, from the lowest: compounds 3 and 1 (each within the scatter of the next); then compound 2.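

Exchanging the group on the ether oxygen for one with the same atoms joined differently gives a 1.8-fold lower number from compound 1 to compound 3 (0.26 log units; within the scatter) in this assay and so opens no gap beyond the scatter at this position. The exchange at the trimethoxyphenyl group, by contrast, gives a 3.5-fold higher number from compound 1 to compound 2 (0.55 log units; beyond the scatter) in this assay as its step. No measurement offers an explanation for either result.

Open, as far as these compounds go, is whether 3,4,5-trimethoxyphenyl would give a similar step when paired with the group carried by compound 3. Also open, from the compounds shown here alone, is how a simple amine or a longer chain on the ether oxygen would read in this assay as a replacement for these two groups.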